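Amide substituent and agonist potency in the series

The source may hold more compounds than are shown below. What is called first, only, known or untested is meant among the compounds shown, and "the series" means these compounds.

Compound 1 `CC#CC(CC(=O)O)c1ccc(OCc2ccc(C(=O)N3CCN(Cc4ccccc4)CC3)s2)cc1` gives 155 nM in a functional assay on HEK293 cells for agonist activity at Free fatty acid receptor 1 (Homo sapiens), read by fluorescence and calcium flux; a lower number here means that less compound is needed, a higher number that more compound is needed for the effect. Compound 3 `CC#CC(CC(=O)O)c1ccc(OCc2ccc(C(=O)N3CCN(c4cccc(F)c4)CC3)s2)cc1` gives 97 nM in this assay, and the change is a 1.6-fold lower number from compound 1 to compound 3 (0.20 log units; within the scatter). Compound 2 `CC#CC(CC(=O)O)c1ccc(OCc2ccc(C(=O)N3CCN(C)CC3)s2)cc1` reaches only the limit of this assay, > 5000 nM, so it stands at the limit of > 5000 nM in this assay, at which 1 of the 3 values shown sits, and no number is known for it. Taking the phenyl away from compound 1 thus gives an at least 32-fold higher number from compound 1 to compound 2 (1.50 log units; beyond the scatter), and putting 3-fluorophenyl in place of the methyl gives an at least 51-fold lower number from compound 2 to compound 3 (1.71 log units; beyond the scatter).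

Compound 4 `CC#CC(CC(=O)O)c1ccc(OCc2ccc(C(=O)NC3CCCc4ccccc43)s2)cc1` is not yet measured. Its change from compound 2 is (1,2,3,4-tetrahydronaphthalen-1-yl)amino in place of 4-methylpiperazin-1-yl on a carbonyl carbon. The two measured steps that bear on this are those starting or ending at compound 2: both were large and both showed that an aromatic ring in the group on the carbonyl carbon goes with a far lower number than the methylpiperazine does. Compound 4 again carries an aromatic ring in that group, so a large step downward in this assay is expected, of roughly an at least 20-fold lower number from compound 2 to compound 4 (1.30 log units; beyond the scatter). The estimate for compound 4 is 250 nM, with a range from 60 nM to 1500 nM.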

Compound 4, half-maximal effective concentration: 109 nM
Estimate against measurement, compound 4: 2.3-fold (0.36 log units) above; the measured number falls inside the stated range.
By their numbers in this assay, from the lowest: compounds 3, 4 and 1 (each within the scatter of the next). At a limit, above all of these: compound 2.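

In this assay, replacing 4-methylpiperazin-1-yl with (1,2,3,4-tetrahydronaphthalen-1-yl)amino gives an at least 45-fold lower number from compound 2 to compound 4 (1.66 log units; beyond the scatter). Among the earlier compounds, numbers well below the limit came only with a piperazine ring on the carbonyl carbon, whereas compound 4 has no such ring, carrying instead a carbon-only non-aromatic ring, an aromatic ring and the amide hydrogen, and it still stands within the scatter of compound 3 and compound 1, so the piperazine ring is not needed for a low number among the compounds shown. Compound 2 has a limit and not a number, so the size of this step remains a bound: the limit of > 5000 nM in this assay, at which 1 of the 4 values shown sits.

The compounds shown do not separate the roles of the amide hydrogen, the non-aromatic ring and the aromatic ring within the entering group, a question that a benzylamino, a cyclohexylamino or an N-methyl-N-benzylamino group on the carbonyl carbon would address. It also remains open whether an aromatic ring is needed at all, since the only group shown without one, 4-methylpiperazin-1-yl, also differs from the others in other ways.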